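A few compounds are considered here, and "the series" means these few. Any claim that something is new, unique, unknown or untested is made for them only; others in the source may bear on it.

Measured so far:
compound 1 `COc1cc(/C=C/C(C)=O)ccc1OCc1cn(-c2ccccc2Cl)nn1` — 48000 nM
compound 2 `COc1cc(/C=C/C(C)=O)ccc1OCc1cn(-c2ccc(-c3ccccc3)cc2)nn1` — 56800 nM

In a functional assay on PC-3 cells (Homo sapiens) for antiproliferative activity, read by MTT assay, with a stated time of 48 h (on this read-out higher numbers stand for weaker inhibition and lower numbers for stronger inhibition), compound 1 gives 48000 nM. In this assay compound 2 gives 56800 nM, the higher of the two numbers, but the gap to compound 1 lies within the scatter, so the two compounds are read as equivalent here; both sit in the weak range of this read-out.

Compound 3 `COc1cc(/C=C/C(C)=O)ccc1OCc1cn(-c2ccccc2)nn1` is the next member. Relative to compound 2 the change is hydrogen in place of phenyl on an aromatic carbon. For the measured compounds named here, no measured pair shows this step directly. Going by the values given here, the one measured pair, compound 1 against compound 2, shows two different substitution patterns on that ring giving numbers within the scatter of each other, which gives no sign that this ring drives the read-out in either direction. The step of a 1.3-fold lower number from compound 2 to compound 3 (0.10 log units; within the scatter) is therefore expected to be small, within or barely beyond the scatter, with no firm direction. Compound 3 is expected to give 45000 nM, in the range 18000 nM to 110000 nM.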

Compound 3, half-maximal inhibitory concentration: 78600 nM
The estimate for compound 3 lay 1.7-fold (0.24 log units) below the measured number, and the stated range covers the measured number.
By their numbers in this assay, from the lowest: compounds 1, 2 and 3 (each within the scatter of the next).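

Hydrogen in place of phenyl gives a 1.4-fold higher number from compound 2 to compound 3 (0.14 log units; within the scatter) in this assay, and hydrogen in place of chloro gives a 1.6-fold higher number from compound 1 to compound 3 (0.21 log units; within the scatter) in the same read-out; both steps lie within the scatter. Compound 3 thus supplies the hydrogen reference that the first two compounds lacked, and against it neither the phenyl of compound 2 nor the chloro of compound 1 can be told apart from hydrogen. Across these three compounds, a substituent as large as phenyl and one as small as chloro both leave the number in the weak range of this read-out, so no substituent shown here separates from the unsubstituted ring. Nothing available bears on why these numbers fall where they do.

Still open, on these data alone, is whether a different kind of group on this ring, such as an amine or a carboxylic acid, would produce a step beyond the scatter. The compounds shown also leave the shared core untouched, so they say nothing about how its methoxy group or its side chain contributes to the read-out.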